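Aryl in place of hydrogen on the shared core: cytotoxicity outlook

This account rests on a few compounds, and the source may have more. Where it says the series, first, only, none or still open, it means among the compounds named here.

Of the compounds shown here, two have been measured in an ADME assay on cells (Macrophage, Mus musculus) for cytotoxicity; a lower number here means that less compound is tolerated, a higher number that more compound is tolerated. Compound 1 `Nc1ncnn2c([C@@H]3O[C@H](CO)[C@@H](O)[C@H]3O)cc(Br)c12` gives 2000 nM in this assay. Compound 2 `Nc1ncnn2c([C@@H]3O[C@H](CO)[C@@H](O)[C@H]3O)ccc12` differs from it by hydrogen in place of bromo on an aromatic carbon. In this assay compound 2 reaches only a limit, < 250 nM, so where compound 2 truly stands is not known. Within the data shown here, the single measured step, an at least 8.0-fold lower number from compound 1 to compound 2 (0.90 log units; beyond the scatter), is therefore bounded on one side only; the limit of < 250 nM in this assay, at which 1 of the 2 values shown sits, marks that one of the two values is such a limit. What the data show is that removing bromo from that carbon made the cells tolerate markedly less compound.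

Compound 3 `Nc1ncnn2c([C@@H]3O[C@H](CO)[C@@H](O)[C@H]3O)cc(-c3ccc(Cl)c(F)c3)c12` is not yet measured. Its change from compound 2 is 4-chloro-3-fluorophenyl in place of hydrogen on an aromatic carbon. Among the measured compounds shown here, the only comparison that bears on it is the bromo-to-hydrogen step, which runs the other way and was at least modest; a substituent returned to that carbon is expected to move the number back up, by roughly that size or more, though its exact size is uncertain since it starts from a limit. The expected step is an at least 6.0-fold higher number from compound 2 to compound 3 (0.77 log units; beyond the scatter). Compound 3 is therefore estimated at 1500 nM, with a range from 250 nM to 8000 nM.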

Compound 3, half-maximal cytotoxic concentration: > 64000 nM
Compound 3: no number, only a limit; the forecaster's own chance of this, stated with the estimate: 15%; middle value at least 42-fold (1.63 log units) from the limit.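

Set on the aromatic carbon two ring bonds from the ring nitrogen, 4-chloro-3-fluorophenyl in place of bromo gives an at least 32-fold higher number from compound 1 to compound 3 (1.50 log units; beyond the scatter) in this assay, and in place of hydrogen it gives an at least 250-fold higher number from compound 2 to compound 3 (2.40 log units; beyond the scatter). The three compounds now run in one direction at this carbon, with hydrogen in compound 2, bromo in compound 1 and the aryl group in compound 3, so that a whole aromatic ring takes the tolerated concentration far past the gain that bromo alone had shown. Both steps are bounded on one side only, and their true size remains unknown, since compound 3 reaches only a limit: the limit of > 64000 nM in this assay, at which 1 of the 3 values shown sits.

Among these compounds, compound 3 is the only aryl example here, so the values do not tell whether the shift belongs to a six-membered aromatic ring as such or needs the chlorine and fluorine on it. As far as these compounds go, how an unsubstituted phenyl, a methyl, an amine or a carboxylic acid on the same carbon would fall between compound 2 and compound 3 stays open.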